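Trading a pentyl chain for a hydroxy group

The source may report more compounds than this note shows. Statements on the series, on what has been measured and on what is new or still open speak of the compounds shown alone.

In a functional assay on SW480 cells (Homo sapiens) for antiproliferative activity, read by MTT assay, with a stated time of 48 h (a lower number here means a stronger inhibitor, a higher number a weaker inhibitor), compound 2 `CCCCCCC(CCO)n1cnc2c(Cl)ncnc21` gives 16700 nM and compound 1 `CCCCCCC(CCO)n1cnc2c(Cl)nc(F)nc21` gives 12900 nM in the same assay. Hydrogen in place of fluoro on an aromatic carbon brings a 1.3-fold higher number from compound 1 to compound 2 (0.11 log units; within the scatter) so these two compounds stand level.

Compound 3 `CCCCCCC(CCO)n1cnc2c(N(C)C)ncnc21` reports > 50000 nM as its result, which is a limit of the assay and not a number. Dimethylamino in place of chloro on an aromatic carbon brings an at least 2.9-fold higher number from compound 2 to compound 3 (0.47 log units; beyond the scatter) as the only clear step so far.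

Compound 4 `OCCC(CO)n1cnc2c(Cl)ncnc21` keeps the core of compound 2 but carries hydroxy in place of pentyl on a saturated chain carbon, two bonds along the chain from an aromatic nitrogen as its one difference. Neither measured step touches the chain, so both serve only as rough guides to size. A modest rise in the number in this assay is expected, meaning a weaker compound, sized on the clear step to compound 3 an at least 2.9-fold higher number from compound 2 to compound 3 (0.47 log units; beyond the scatter) rather than on the flat one. Compound 4 could also end at the limit of > 50000 nM in this assay, at which 1 of the 3 values shown sits, and give no number. The expected change is a 2.1-fold higher number from compound 2 to compound 4 (0.32 log units; beyond the scatter) and it remains loosely bounded. For compound 4 the estimated value is 35000 nM (expected range 14000 nM to 80000 nM).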

Compound 4, half-maximal inhibitory concentration: > 50000 nM
Compound 4: only a limit was reported; the forecaster's own chance of this, stated with the estimate: 45%; middle value at least 1.4-fold (0.15 log units) away from the limit.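

Until now only groups on the shared core had changed; this result shows that the chain matters too. In this assay, replacing a pentyl group of five carbons with a single hydroxy, on a saturated chain carbon, two bonds along the chain from an aromatic nitrogen, brings an at least 2.9-fold higher number from compound 2 to compound 4 (0.47 log units; beyond the scatter), so compound 2 cannot lose this pentyl without a clear drop in activity. Compound 4 ends at a limit and not at a number, so the step gives only a minimum size and cannot be ranked against the step to compound 3, and the compounds shown now gather at that limit: the limit of > 50000 nM in this assay, at which 2 of the 4 values shown sit.

What the compounds shown leave open is whether the pentyl group itself matters or whether the hydroxy is what costs the activity, since this one change removes the first and adds the second; a methyl, a propyl chain or a longer chain such as octyl at this place would begin to separate the two. On these data alone, it is also open whether an amine or a methoxy group in place of the hydroxy would behave the same way.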